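Swapping Carbamoyl for Phenyl on the Saturated Ring

A few compounds are considered here, and "the series" means these few. Any claim that something is new, unique, unknown or untested is made for them only; others in the source may bear on it.

Of the compounds shown here, three sharing one core have been tested in a functional assay on SQ20B cells (Homo sapiens) for cytotoxicity, read by MTT assay, with a stated time of 72 h; on this read-out higher numbers stand for weaker inhibition and lower numbers for stronger inhibition. Compound 1 `Oc1ccc2oc(Cc3ccccc3)cc2c1CN1CCCC(O)C1` gives 11000 nM, compound 2 `Oc1ccc2oc(Cc3ccccc3)cc2c1CN1CCC(O)CC1` gives 13000 nM, and compound 3 `NC(=O)C1CCN(Cc2c(O)ccc3oc(Cc4ccccc4)cc23)CC1` gives 85000 nM. Compound 3 stands highest of the three, and both steps toward it lie beyond the scatter: a 7.7-fold higher number from compound 1 to compound 3 (0.89 log units; beyond the scatter) and a 6.5-fold higher number from compound 2 to compound 3 (0.82 log units; beyond the scatter). The step between the two hydroxy-bearing compounds, a 1.2-fold higher number from compound 1 to compound 2 (0.07 log units; within the scatter), is within the scatter.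

Compound 4 `Oc1ccc2oc(Cc3ccccc3)cc2c1CN1CCC(c2ccccc2)CC1` has not yet been measured. It differs from compound 3 in one place: phenyl in place of carbamoyl on a saturated ring carbon. Going by the values given here, no measured pair shows a phenyl entering, so the one step that bears directly on it is a 6.5-fold higher number from compound 2 to compound 3 (0.82 log units; beyond the scatter), where a carbamoyl took the place of a hydroxy on a saturated ring carbon and the number rose. Among the compounds with values here, removing that carbamoyl is expected to let the number fall again because a 6.5-fold higher number from compound 2 to compound 3 (0.82 log units; beyond the scatter) went the other way, but how far a phenyl carries it has no precedent here, so the range is wide. The expected step is a 7.1-fold lower number from compound 3 to compound 4 (0.85 log units; beyond the scatter), toward a lower number. Compound 4 is therefore estimated at 12000 nM in this assay, with a range from 3000 nM to 50000 nM.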

Compound 4, half-maximal inhibitory concentration: > 200000 nM
Compound 4: no number, only a limit (the forecaster's own chance of this, stated with the estimate: 5%); middle value at least 16-fold (1.22 log units) away from the limit.
By their numbers in this assay, from the lowest: compounds 1 and 2 (each within the scatter of the next); then compound 3. At a limit, above all of these: compound 4.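

At this saturated ring carbon, three ring bonds from the ring nitrogen, the change has pushed the read-out past what the assay could put a number on, so compound 4 has only a limit: (the limit of > 200000 nM in this assay, at which 1 of the 4 values shown sits). The earlier compounds shown here showed a carbamoyl raising the number relative to a hydroxy, but phenyl in place of carbamoyl raised it further (an at least 2.3-fold higher number from compound 3 to compound 4 (0.37 log units; beyond the scatter)), and phenyl in place of hydroxy gave a large step in the same direction (an at least 15-fold higher number from compound 2 to compound 4 (1.18 log units; beyond the scatter)). So on this carbon, moving away from the hydroxy-bearing compounds has now twice meant a loss of cytotoxicity, and swapping out the carbamoyl brought no recovery, even though phenyl shares neither its hydrogen-bond donor nor its acceptor.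

Phenyl differs from carbamoyl at once in its heavy atom count, its aromatic ring and its lack of hydrogen-bond donors and acceptors, and these compounds cannot tell which of those differences matters. A cyclohexyl group, which keeps a six-membered ring without the aromatic one, or a primary amine or carboxylic acid on the same carbon would begin to pull those features apart.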